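The source may report more compounds than this note shows. Statements on the series, on what has been measured and on what is new or still open speak of the compounds shown alone.

Working notes on the series. Compound 1 `COc1ccc(/C=C\C(=O)O)c(OCc2cn(-c3ccccc3F)nn2)c1CC=C(C)C` in a functional assay on HCT-116 cells (Homo sapiens) for cytotoxicity, read by MTT assay, with a stated time of 24 h (on this read-out lower numbers stand for stronger inhibition and higher numbers for weaker inhibition), is recorded as "not determined" (no result reported), so no result is reported for it. Compound 2 `COc1ccc(/C=C\C(=O)O)c(OCc2cn(-c3ccc(CO)cc3)nn2)c1CC=C(C)C` in this assay gives 31700 nM. Compound 3 `COc1ccc(/C=C\C(=O)O)c(OCc2cn(-c3ccc(C#N)cc3)nn2)c1CC=C(C)C` in this assay gives 21000 nM. Among the compounds with values here, the only step between measured compounds, a 1.5-fold lower number from compound 2 to compound 3 (0.18 log units; within the scatter), does not separate the two. Compound 3 therefore holds the lower of the two numbers shown, but its gap to compound 2 is within the scatter, so no order between them is claimed; compound 1 stands aside without a number.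

Compound 4 `COc1ccc(/C=C\C(=O)O)c(OCc2cn(-c3nc4ccccc4s3)nn2)c1CC=C(C)C` differs from compound 3 by 1,3-benzothiazol-2-yl in place of 4-cyanophenyl on an aromatic nitrogen. Within the data shown here, no measured step covers this kind of change: the one step available, a 1.5-fold lower number from compound 2 to compound 3 (0.18 log units; within the scatter), exchanges a substituent on the same six-membered carbon ring and stayed within the scatter, whereas here the whole group on the triazole nitrogen is replaced by a bicyclic heteroaryl. With nothing in the measured pairs pointing up or down, the step of a 1.1-fold lower number from compound 3 to compound 4 (0.02 log units; within the scatter) is expected to stay within the scatter, with a wide range to allow for the untested nature of the exchange. The estimate for compound 4 in this assay is accordingly 20000 nM, within 7000 nM to 55000 nM.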

Compound 4, half-maximal inhibitory concentration: 16400 nM
Compound 4: middle estimate off by 1.2-fold (0.09 log units), on the high side; the measured number falls inside the stated range.
By their numbers in this assay, from the lowest: compounds 4, 3 and 2 (each within the scatter of the next).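

The earlier step only exchanged a substituent on a six-membered carbon ring, whereas compound 4 replaces the entire 4-cyanophenyl on the aromatic nitrogen with 1,3-benzothiazol-2-yl, which brings in a five-membered aromatic ring with 2 hetero atoms and sulfur. In this assay, this larger exchange gives a 1.3-fold lower number from compound 3 to compound 4 (0.11 log units; within the scatter), so even a change of the whole group at this position does not separate the two compounds. The comparison with the 4-(hydroxymethyl)phenyl group gives a 1.9-fold lower number from compound 2 to compound 4 (0.29 log units; within the scatter), which also does not separate them, and no measured evidence bears on this result.

The compounds shown all carry an aromatic group on this nitrogen and remain within the scatter of their neighbours, so this position has not yet produced a difference that can be read. As far as these compounds go, it remains open whether a group of another kind here, such as a basic amine on a saturated ring, a carboxylic acid on the aryl group or a longer alkyl chain, would move the number beyond the scatter.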